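Swapping the Amine Substituent of Compound 1

This account rests on a few compounds, and the source may have more. Where it says the series, first, only, none or still open, it means among the compounds named here.

Compound 1, `CCc1nc(-c2ccc(Cl)cc2Cl)c(CC)nc1NC(C1CC1)C1CC1`: 3.7 nM
Compound 2, `CCOc1ccc(-c2nc(OC)c(NC(CC)CC)nc2C)c(Cl)c1`: 5.9 nM

In an assay on IMR-32 cells for displacement of a labelled ligand from corticotropin-releasing factor receptor 1 (Homo sapiens), read by scintillation counting, with a stated time of 2 h (on this read-out higher numbers stand for weaker inhibition and lower numbers for stronger inhibition), compound 1 gives 3.7 nM, the lower of the two numbers recorded. Compound 2 gives 5.9 nM, a difference that sits within the scatter, so neither compound can be called the stronger binder. Compound 3, `CCc1nc(-c2ccc(Cl)cc2Cl)c(CC)nc1NC(CC)CC`, is not yet measured. It differs from compound 1 in one place: pentan-3-yl in place of dicyclopropylmethyl on a nitrogen on an aromatic ring. Within the data shown here, no measured pair shows this change directly, and compound 2 carries a pentan-3-yl group on a different core, so it offers only a loose hint that such an amine is compatible with tight binding. The account therefore expects no step beyond the scatter in this assay, with at most a slight drift toward a higher number. Compound 3 is expected to give about 5.5 nM, within a range from 1.8 nM to 17 nM. The expected step is a 1.5-fold higher number from compound 1 to compound 3 (0.17 log units; within the scatter).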

Compound 3, inhibition constant: 4.1 nM
Beside the measured number, compound 3's estimate is 1.3-fold (0.13 log units) above it; the range from low to high includes it.
By their numbers in this assay, from the lowest: compounds 1, 3 and 2 (each within the scatter of the next).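

Among these compounds, the step of a 1.1-fold higher number from compound 1 to compound 3 (0.04 log units; within the scatter) is the first direct reading of this position on the shared core, and in this assay it stays within the scatter. Pentan-3-yl, with no ring, therefore serves here as well as dicyclopropylmethyl, so the two three-membered rings are not needed on this core for a value in this range. Nothing at hand explains why the two groups read alike.

The compounds shown leave open how much further this amine substituent can vary, for instance whether a shorter isopropyl group, a longer chain, or a methoxyethyl group carrying an ether oxygen would keep the value on the core of compound 1. They also leave open whether dicyclopropylmethyl and pentan-3-yl would read alike on the core of compound 2.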